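Trifluoromethyl for Methoxy on the Benzoyl Group

The source may report more compounds than this note shows. Statements on the series, on what has been measured and on what is new or still open speak of the compounds shown alone.

Compound 1, `COc1cc(C(=O)C2Sc3nnc(-c4cc(OC)c(OC)c(OC)c4)n3NC2c2ccco2)cc(OC)c1OC`, in a functional assay on HepG2 cells (Homo sapiens) for cytotoxicity, read by MTT assay, with a stated time of 48 h (on this read-out lower numbers stand for stronger inhibition and higher numbers for weaker inhibition), gives > 100000 nM, which is a limit of the assay.
Compound 2, `COc1cc(-c2nnc3n2NC(c2ccco2)C(C(=O)C2CC2)S3)cc(OC)c1OC`, in this assay gives > 100000 nM, which is a limit of the assay.
Compound 3, `COc1ccc(C(=O)C2Sc3nnc(-c4cc(OC)c(OC)c(OC)c4)n3NC2c2ccco2)cc1`, in this assay gives > 100000 nM, which is a limit of the assay.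

Compound 3 stands exactly where the other two measured compounds stand, namely at the limit of > 100000 nM in this assay, at which 3 of the 3 values shown sit. Among the compounds with values here, no step among the three can be read: a step that the two limits leave unreadable from compound 1 to compound 2, a step that the two limits leave unreadable from compound 1 to compound 3 and a step that the two limits leave unreadable from compound 2 to compound 3 each run from one limit to another, so their size stays hidden.

Compound 4, `COc1cc(-c2nnc3n2NC(c2ccco2)C(C(=O)c2ccc(C(F)(F)F)cc2)S3)cc(OC)c1OC`, differs from compound 3 by trifluoromethyl in place of methoxy on an aromatic carbon. The measured steps that bear on this position are the three changes of the group on the carbonyl carbon just named, and all of them left every compound at the limit. Nothing among these measurements shows a change at this position bringing a value into the readable range. The step from compound 3 to compound 4 is therefore expected to be a number no higher from compound 3 to compound 4 (the limit leaves the size open), no more than the scatter. Compound 4 is estimated in this assay at 100000 nM, within a range from 30000 nM to 300000 nM, and is expected most likely to be reported again only as a limit.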

Compound 4, half-maximal inhibitory concentration: > 100000 nM
Compound 4: only a limit was reported; the forecaster's own chance of this, stated with the estimate: 80%; the middle value lies on the limit itself.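

Within the data shown here, no step from compound 1, compound 2 or compound 3 to compound 4 can be read, since each runs from one limit to another: the limit of > 100000 nM in this assay, at which 4 of the 4 values shown sit.

The compounds shown leave open how far apart these four actually lie, and whether any change of the group on the carbonyl carbon could bring a value into the readable range.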